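A few compounds are considered here, and "the series" means these few. Any claim that something is new, unique, unknown or untested is made for them only; others in the source may bear on it.

Values so far in a functional assay on MCF7 cells (Homo sapiens) for inhibition, read by MTT assay, with a stated time of 24 h; a higher number here means a weaker inhibitor, a lower number a stronger inhibitor
Compound 1 `CCc1ccc(/C=C/[C@@H]2CCCCN2)cc1` gives 4.13 ug/mL
Compound 2 `FC(F)(F)c1ccc(/C=C/[C@@H]2CCCCN2)cc1` gives 1.25 ug/mL
Compound 3 `Cc1cccc(C)c1/C=C/[C@@H]1CCCCN1` gives 4.29 ug/mL

Compound 2 has the lowest number of the three, which makes it the strongest inhibitor measured so far. Compound 3 differs from compound 2 in more than one place, so it offers no clean single-change comparison.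

Compound 4 `CC(=O)c1ccc(/C=C/[C@@H]2CCCCN2)cc1` has not yet been measured. It differs from compound 2 in one place, with acetyl in place of trifluoromethyl on an aromatic carbon.

Within the data shown here, only one measured step changes a group on that same carbon, a 3.3-fold lower number from compound 1 to compound 2 (0.52 log units; beyond the scatter). This modest step shows that the number at this carbon can move beyond the scatter. Read in reverse, it suggests that losing trifluoromethyl may raise the number. Acetyl itself is untested, so that single step is only a rough guide, and a rise of similar or somewhat smaller size seems likely in this assay.

The expected change is a 2.2-fold higher number from compound 2 to compound 4 (0.35 log units; beyond the scatter). For compound 4 the estimated value is 2.8 ug/mL, with an expected range from 1.1 ug/mL to 7 ug/mL.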

Compound 4, half-maximal inhibitory concentration: 2.7 ug/mL
The estimate for compound 4 lay 1.0-fold (0.02 log units) above the measured number; the range from low to high includes it.
By their numbers in this assay, from the lowest: compound 2; then compounds 4, 1 and 3 (each within the scatter of the next).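

In this assay, putting acetyl on this aromatic carbon in place of trifluoromethyl gives a 2.2-fold higher number from compound 2 to compound 4 (0.33 log units; beyond the scatter), so a second group now shows a weaker result than trifluoromethyl, and the earlier ethyl result was not a one-off. Exchanging ethyl for acetyl gives a 1.5-fold lower number from compound 1 to compound 4 (0.18 log units; within the scatter), so these two groups cannot be told apart in this assay, even though acetyl brings a carbonyl that ethyl lacks. Of the three groups shown at this carbon, trifluoromethyl alone stands apart, with ethyl and acetyl together at higher numbers.

No measurement at hand explains why trifluoromethyl gives the lower number. As far as these compounds go, it remains open whether an amine, a carboxylic acid or a single fluorine on this carbon would match trifluoromethyl or group with ethyl and acetyl.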